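The compounds below may be only part of what the source reports. "The series", "measured", "known", "first", "only" and "open" are said of these compounds alone.

Going by the values given here, compound 2 `COc1cc2cc(Oc3ccc(NC(=O)Nc4ccc(Cl)c(C(F)(F)F)c4)cc3)c(C)nc2cc1OC` gives the lowest of the two numbers so far in a functional assay on MDA-MB-231 cells (Homo sapiens) for inhibition, read by sulforhodamine B assay, with a stated time of 48 h (on this read-out lower numbers stand for higher toxicity in this test and higher numbers for lower toxicity in this test), at 9600 nM; compound 1 `COc1cc2cc(Oc3ccc(NC(=O)Nc4cccc(C(F)(F)F)c4)cc3)c(C)nc2cc1OC` gives 18600 nM, and the step of a 1.9-fold lower number from compound 1 to compound 2 (0.29 log units; within the scatter) stays within the scatter. Compound 3 `COc1cc2cc(Oc3ccc(NC(=O)Nc4ccc(Cl)c(Cl)c4)cc3)c(C)nc2cc1OC` differs from compound 2 by chloro in place of trifluoromethyl on an aromatic carbon. Among the compounds with values here, no measured pair exchanges these two groups; the only known step, hydrogen to chloro, stayed within the scatter, so no change beyond the scatter is expected for compound 3, a step of a 1.0-fold higher number from compound 2 to compound 3 (0.02 log units; within the scatter). Compound 3 is therefore estimated at 10000 nM, with a range from 4000 nM to 25000 nM.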

Compound 3, concentration lethal to 50% of the cells: 34600 nM
Compound 3: middle estimate off by 3.5-fold (0.54 log units), on the low side; measured number outside the range, above it.
By their numbers in this assay, from the lowest: compounds 2, 1 and 3 (each within the scatter of the next, the first and the last beyond it).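

In this assay, going by these compounds alone, chloro in place of trifluoromethyl at this position gives a 3.6-fold higher number from compound 2 to compound 3 (0.56 log units; beyond the scatter), the first step here beyond the scatter, so this position does respond to the group it carries. Yet 3,4-dichlorophenyl in place of 3-(trifluoromethyl)phenyl gives a 1.9-fold higher number from compound 1 to compound 3 (0.27 log units; within the scatter), so this exchange, made together with the added chloro, stays within the scatter, and the effect of the exchange shows only in the presence of the 4-chloro group of compound 2. No measurement offers an explanation for this difference. The compounds shown leave open how an amine or a carboxylic acid at this position would read in this assay.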